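Amine substituent series on the shared core: butyl to cyclopentyl

The compounds below may be only part of what the source reports. "The series", "measured", "known", "first", "only" and "open" are said of these compounds alone.

Measured compounds:
compound 1 `CC(Nc1nnc2nncn2n1)C(=O)O` gives 82200 nM in a functional assay on BeWo cells (Homo sapiens) for inhibition, read by MTT assay, with a stated time of 72 h; on this read-out lower numbers stand for stronger inhibition and higher numbers for weaker inhibition
compound 2 `CCCCNc1nnc2nncn2n1` gives 8640 nM in this assay
compound 3 `CC(C)C(=O)N1CCN(c2nnc3nncn3n2)CC1` gives 1090 nM in this assay

Compound 2 stands second highest of the three numbers in this assay: compound 3 lies below it and compound 1 above it, both gaps beyond the scatter. Within the data shown here, the one measured step that touches compound 2 is a 9.5-fold lower number from compound 1 to compound 2 (0.98 log units; beyond the scatter), a change of the group on the amine nitrogen.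

Compound 4 `c1nnc2nnc(NC3CCCC3)nn12` differs from compound 2 by cyclopentyl in place of butyl on a nitrogen on an aromatic ring. Among the measured compounds shown here, no measured step exchanges one hydrocarbon group for another on this nitrogen, so the direction of the step is not fixed by the data; a small change, possibly within the scatter, is expected, written as a 1.4-fold lower number from compound 2 to compound 4 (0.16 log units; within the scatter). Compound 4 is estimated at 6000 nM, with a range from 2000 nM to 20000 nM.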

Compound 4, half-maximal inhibitory concentration: 34700 nM
The estimate for compound 4 lay 5.8-fold (0.76 log units) below the measured number; the whole stated range lies below it.
By their numbers in this assay, from the lowest: compound 3; then compound 2; then compound 4; then compound 1.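

In this assay, exchanging one hydrocarbon group for another on this nitrogen is not a neutral change: a 4.0-fold higher number from compound 2 to compound 4 (0.60 log units; beyond the scatter), with cyclopentyl replacing butyl. Cyclopentyl also stays ahead of the acid-bearing group, with a 2.4-fold lower number from compound 1 to compound 4 (0.37 log units; beyond the scatter), so the lower number seen on leaving 1-carboxyethyl holds for both hydrocarbon groups but is smaller with the ring. The compounds shown leave open how a longer chain, a branched chain or a cyclohexyl ring would stand on this nitrogen. No supporting data explain the difference between butyl and cyclopentyl.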